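This account rests on a few compounds, and the source may have more. Where it says the series, first, only, none or still open, it means among the compounds named here.

Of the compounds shown here, two built on the same core have been tested in an ADME assay on HepG2 2.2.15 cells (Homo sapiens) for cytotoxicity; a lower number here means that less compound is tolerated, a higher number that more compound is tolerated. Compound 1, `Cn1c(=O)c(CCO)c(-c2ccccc2Cl)c2cc(Cl)ccc21`, gives 34000 nM. Compound 2, `O=C(OCCc1c(-c2ccccc2Cl)c2cc(Cl)ccc2[nH]c1=O)C1CCCC1`, gives 46000 nM; on these two numbers compound 2 stands alongside compound 1, the difference between them lying within the scatter of repeated measurements, so neither is set apart. Going by the values given here, no step between measured compounds is available as a guide. Compound 3, `O=C(/C=C/c1cccc(F)c1)OCCc1c(-c2ccccc2Cl)c2cc(Cl)ccc2[nH]c1=O`, differs from compound 2 by 2-(3-fluorophenyl)ethenyl in place of cyclopentyl on a carbonyl carbon. A modest step, or none beyond the scatter, is expected for a 1.5-fold lower number from compound 2 to compound 3 (0.19 log units; within the scatter). Compound 3 is estimated at 30000 nM, within 12000 nM to 75000 nM.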

Compound 3, half-maximal cytotoxic concentration: > 1600000 nM
Compound 3 ended at the assay's limit; the forecaster's own chance of this, stated with the estimate: 15%; middle value at least 53-fold (1.72 log units) away from the limit.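

Placing 2-(3-fluorophenyl)ethenyl instead of cyclopentyl on this carbonyl carbon gives an at least 34-fold higher number from compound 2 to compound 3 (1.54 log units; beyond the scatter), so in this assay the group here can change by a wide margin how much compound is tolerated, which compounds 1 and 2 could not show. Compound 3 stands at a limit of the assay, not at a number: the limit of > 1600000 nM in this assay, at which 1 of the 3 values shown sits.

The compounds shown leave open whether the fluorine, the double bond or the aromatic ring carries this step. From the compounds shown here alone, how an amine or a longer carbon chain on this carbonyl carbon would read also stays open.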